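The compounds below may be only part of what the source reports. "The series", "measured", "known", "first", "only" and "open" are said of these compounds alone.

Working notes on the series. Three compounds have been run in a functional assay on the whole organism (Tail, strain ICR) with Mus musculus as the target, in the tail flick test, with a stated time of 30 min, at a dose of 25 umol/kg by the oral route; a higher number here means a stronger effect of the compound at the dose given, a lower number a weaker effect. Compound 1 `O=C(O)[C@@H]1CCCN1C(=O)CN(c1nc(Cl)nc2[nH]cnc12)C1CC1` gives 31.5% in this assay. Compound 2 `O=C(CN(c1nc(Cl)nc2[nH]cnc12)C1CC1)NCC(=O)OCc1ccccc1` gives 18.7% in this assay, the lowest of the three numbers, with both others standing beyond the scatter above it. Among the measured compounds shown here, compound 3 `O=C(CN(c1ncnc2c1ncn2C1CCCCO1)C1CC1)N[C@@H](CCC(=O)OCc1ccccc1)C(=O)OCc1ccccc1` gives 32.6% in this assay, the highest number so far but within the scatter of compound 1, so no order between compounds 1 and 3 is claimed.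

The step followed here goes from compound 2 to the unmeasured compound 4 `NCCCC[C@H](NC(=O)CN(c1nc(Cl)nc2[nH]cnc12)C1CC1)C(=O)OCc1ccccc1`. The change is 4-aminobutyl in place of hydrogen on a saturated chain carbon bound to an amide-type nitrogen and a carbonyl carbon. For the measured compounds named here, compounds 1 and 3, which carry more than a bare hydrogen at the corresponding position, both stand above compound 2, though they differ from it in more than one place, so no single step is recorded.

For compound 4 a rise beyond the scatter is expected, estimated as a number 10.3 percentage points higher from compound 2 to compound 4 (beyond the scatter) in this assay. Compound 4 is expected to give about 29% in this assay, with a range from 16% to 42%.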

Compound 4, a percentage reported as activity, at one dose (the size of the read-out at that dose, not a potency): 26.1%
Compound 4: the middle estimate sits 2.9 percentage points above what was measured; the range from low to high includes it.
By their numbers in this assay, from the lowest: compounds 2, 4, 1 and 3 (each within the scatter of the next, the first and the last beyond it).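

The series now has its first step that differs in one place: with 4-aminobutyl in place of hydrogen on a saturated chain carbon bound to an amide-type nitrogen and a carbonyl carbon, this assay gives a number 7.4 percentage points higher from compound 2 to compound 4 (within the scatter). The position therefore carries this chain, terminal amine included, with the read-out still inside the scatter of the hydrogen compound, so neither a gain nor a loss can be claimed for the group. Nothing on hand bears on what lies behind this step.

Open, on these data alone, is whether a methyl group or a shorter aminoalkyl chain on the same carbon would stand apart from compound 2 beyond the scatter. Also open, as far as these compounds go, is whether a carboxylic acid or an acetamide at the end of the chain would read differently from the amine of compound 4.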